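The compounds below may be only part of what the source reports. "The series", "measured", "known", "first", "only" and "open" are said of these compounds alone.

Measured compounds:
compound 1 `CNc1ncc2c(-c3ccc(N4CCNCC4)nc3)nn(Cc3cn(Cc4ccccc4)nn3)c2n1`, 400 nM in an assay for inhibition of tyrosine-protein kinase receptor UFO (Homo sapiens), read by 33P incorporation, in the presence of a further agent that is not named here; on this read-out lower numbers stand for stronger inhibition and higher numbers for weaker inhibition
compound 2 `CNc1ncc2c(-c3ccc(N4CCN(C(=O)C(C)(C)C)CC4)nc3)nn(Cc3cn(Cc4ccccc4)nn3)c2n1`, 760 nM in this assay

Compound 2 gives the highest number of the two in this assay, and the step of a 1.9-fold higher number from compound 1 to compound 2 (0.28 log units; within the scatter) is within the scatter. Compound 3 `CNc1ncc2c(-c3ccc(N4CCN(C(=O)C(C)(C)C)CC4)nc3)nn(CC3CCCC3)c2n1` differs from compound 2 by cyclopentyl in place of 1-benzyl-1H-1,2,3-triazol-4-yl on a saturated chain carbon bound to an aromatic nitrogen. Among the compounds with values here, no measured step touches the group on the saturated chain carbon bound to the aromatic nitrogen; the single known step concerns the amine nitrogen in the ring. Within the data shown here, the expectation for compound 3 therefore rests on no direct precedent, and a step of a 1.1-fold higher number from compound 2 to compound 3 (0.02 log units; within the scatter) in this assay is estimated, with a wide range. Compound 3 is estimated at 800 nM, between 200 nM and 3200 nM.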

Compound 3, half-maximal inhibitory concentration: 7200 nM
Beside the measured number, compound 3's estimate is 9.0-fold (0.95 log units) below it; measured number above the stated range.
By their numbers in this assay, from the lowest: compounds 1 and 2 (each within the scatter of the next); then compound 3.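

In this assay, within the data shown here, the group on the saturated chain carbon bound to an aromatic nitrogen proves to matter: cyclopentyl in place of 1-benzyl-1H-1,2,3-triazol-4-yl gives a 9.5-fold higher number from compound 2 to compound 3 (0.98 log units; beyond the scatter) and is the first step here to lie beyond the scatter. No supporting evidence bears on this result.

The compounds shown leave open whether the triazole or its benzyl group accounts for the step. A plain benzyl group or a methyl group on the triazole at this place would separate the two, and the change remains unread with hydrogen on the ring amine nitrogen.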